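A few compounds are considered here, and "the series" means these few. Any claim that something is new, unique, unknown or untested is made for them only; others in the source may bear on it.

Measured in an assay on cell membranes for binding affinity to adenosine receptor A1 (Bos taurus), read by radioligand binding; on this read-out lower numbers stand for stronger inhibition and higher numbers for weaker inhibition:
- compound 1 `c1ccc(Cn2nnc3c(NC4CCCC4)ncnc32)cc1` gives 127 nM
- compound 2 `c1ccc(Cn2nnc3c(NCC4CCCCC4)ncnc32)cc1` gives 2790 nM
- compound 3 `Cc1cccc(Nc2ncnc3c2nnn3Cc2ccccc2)c1` gives 1100 nM

Compound 3 stands second highest of the three numbers; the nearest step to it is a 2.5-fold lower number from compound 2 to compound 3 (0.40 log units; beyond the scatter), the furthest an 8.7-fold higher number from compound 1 to compound 3 (0.94 log units; beyond the scatter). Compound 4 `Clc1cccc(Nc2ncnc3c2nnn3Cc2ccccc2)c1` differs from compound 3 by chloro in place of methyl on an aromatic carbon. Within the data shown here, none of the measured steps alters a substituent on the 3-methylphenyl group: a 22-fold higher number from compound 1 to compound 2 (1.34 log units; beyond the scatter), an 8.7-fold higher number from compound 1 to compound 3 (0.94 log units; beyond the scatter) and a 2.5-fold lower number from compound 2 to compound 3 (0.40 log units; beyond the scatter) each exchange the whole group on the nitrogen, so they give no direct guide to this change. A step within the scatter, with no clear direction, is therefore expected in this assay: a 1.1-fold lower number from compound 3 to compound 4 (0.04 log units; within the scatter). For compound 4 the estimated value in this assay is 1000 nM, range 400 nM to 2500 nM.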

Compound 4, inhibition constant: 463 nM
Beside the measured number, compound 4's estimate is 2.2-fold (0.33 log units) above it; the measured number falls inside the stated range.
By their numbers in this assay, from the lowest: compound 1; then compound 4; then compound 3; then compound 2.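

In this assay, among these compounds, the exchange of chloro for methyl on the aromatic ring is the first change made within the group on the nitrogen, and it gives a 2.4-fold lower number from compound 3 to compound 4 (0.38 log units; beyond the scatter), so this place responds to a single-atom substituent change. Even so, a 3.6-fold higher number from compound 1 to compound 4 (0.56 log units; beyond the scatter) leaves cyclopentyl ahead of 3-chlorophenyl, while a 6.0-fold lower number from compound 2 to compound 4 (0.78 log units; beyond the scatter) puts 3-chlorophenyl well ahead of cyclohexylmethyl. Nothing available explains the difference between chloro and methyl. Going by these compounds, whether bromo, methoxy or trifluoromethyl in the same place would extend this step remains open.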